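Naphthalenyl in Place of Chlorophenyl on a Thiadiazine Series

This account rests on a few compounds, and the source may have more. Where it says the series, first, only, none or still open, it means among the compounds named here.

Of the compounds shown here, two of a shared core have been measured in a functional assay on PC-3 cells (Homo sapiens) for cytotoxicity, read by MTT assay, with a stated time of 48 h; on this read-out lower numbers stand for stronger inhibition and higher numbers for weaker inhibition. Compound 1 `COc1cc(-c2nnc3n2NC(c2ccco2)C(C(=O)c2ccc(Cl)cc2)S3)cc(OC)c1OC` gives 67800 nM, the higher of the two numbers and thus the weaker of the two. Compound 2 `COc1cc(-c2nnc3n2NC(c2cccs2)C(C(=O)c2ccc(C)cc2)S3)cc(OC)c1OC` differs from compound 1 at two positions at once; in this assay compound 2 gives 5090 nM, a gap that lies well beyond the usual scatter, so these two values show that a change at the carbonyl-bearing end and at the adjacent ring can move the number a good deal.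

Compound 3 `COc1cc(-c2nnc3n2NC(c2ccco2)C(C(=O)c2cccc4ccccc24)S3)cc(OC)c1OC` is compound 1 with one change: naphthalen-1-yl in place of 4-chlorophenyl on a carbonyl carbon. Among the measured compounds shown here, no measured pair isolates this single change. The expectation is that compound 3 will move toward a lower number in this assay, with the step of a 2.3-fold lower number from compound 1 to compound 3 (0.35 log units; beyond the scatter) modest and probably not far beyond the scatter. For compound 3 the expected value in this assay is 30000 nM, within a range from 8000 nM to 110000 nM.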

Compound 3, half-maximal inhibitory concentration: > 100000 nM
Compound 3: only a limit was reported; the forecaster's own chance of this, stated with the estimate: 5%; at least 3.3-fold (0.52 log units) between middle value and limit.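

In this assay compound 3 is reported only as a limit, > 100000 nM, and not as an exact number. From the compounds shown here alone, the change gives an at least 1.4-fold higher number from compound 1 to compound 3 (0.16 log units; that floor lies within the scatter), so putting the two-ring naphthalen-1-yl on this carbonyl carbon shows no sign of a lower number, and the true size of any loss remains unknown. The step can be read only as a floor because compound 3 sits at the limit of the assay: the limit of > 100000 nM in this assay, at which 1 of the 3 values shown sits.

The compounds shown leave open how the same core would read with an amine or a carboxylic acid on the phenyl ring at this carbonyl carbon, or with a simple methyl group in place of that ring. Compound 2 changes two places at once, so it cannot settle what the group at this position contributes on its own.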